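Mirror image of compound 1 in the cytotoxicity read-out

A few compounds are considered here, and "the series" means these few. Any claim that something is new, unique, unknown or untested is made for them only; others in the source may bear on it.

From the compounds shown here alone, the series holds three measured compounds and one still open. In a functional assay on PBMC cells (Homo sapiens) for cytotoxicity (a higher number here means a weaker inhibitor, a lower number a stronger inhibitor), compound 1 `Nc1ccn([C@@H]2S[C@H](CO)[C@H]2CO)c(=O)n1` gives <= 1000 nM, which is a limit and not a number. Compound 2 `OC[C@H]1[C@H](n2cnc3c(O)ncnc32)S[C@@H]1CO` gives > 100000 nM, also a limit. Compound 3 `Cc1cn([C@H]2S[C@@H](CO)[C@@H]2CO)c(=O)[nH]c1=O` gives > 100000 nM, again a limit. Compound 1 is therefore the only one of the three whose limit sits on the strong-inhibitor side, and none of the three has an exact value.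

Compound 4 `Nc1ccn([C@H]2S[C@@H](CO)[C@@H]2CO)c(=O)n1` is the next case. Set against compound 1, the change is the two compounds have the same atoms and bonds and differ only in configuration as drawn: 3 of 3 stereo elements differ (all stereocentres are inverted: mirror images); a stereocentre at a saturated ring carbon is drawn R in compound 1 and S in compound 4; a stereocentre at a saturated ring carbon is drawn S in compound 1 and R in compound 4; a stereocentre at a saturated ring carbon is drawn R in compound 1 and S in compound 4. No group leaves or enters, so the comparison concerns configuration alone. Among the compounds with values here, no measured pair shows what inverting all stereocentres does, so any expectation here is loose.

In this assay a step toward weaker inhibition, beyond the scatter, is expected, though its size is poorly fixed. Within the data shown here, that lean rests only on the spread of the values so far, namely the limit of <= 1000 nM in this assay, at which 1 of the 3 values shown sits, and (the limit of > 100000 nM in this assay, at which 2 of the 3 values shown sit). The expected step of an at least 20-fold higher number from compound 1 to compound 4 (1.30 log units; beyond the scatter) is an estimate measured from a limit and carries the same looseness. Compound 4 is expected at about 20000 nM, with an estimated range from 1000 nM to 100000 nM.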

Compound 4, half-maximal inhibitory concentration: 13100 nM
Compound 4: middle estimate off by 1.5-fold (0.18 log units), on the high side; measured number inside the range.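

In this assay the series now holds its first readable pair, and the step is an at least 13-fold higher number from compound 1 to compound 4 (1.11 log units; beyond the scatter), a lower bound measured from the limit of compound 1. Within the data shown here, this step can be assigned to configuration alone, because no group leaves or enters and the core stays the same: the fact that compounds 1 and 4 differ only in the configuration as drawn Compound 4 gives 13100 nM, the first exact number, so the mirror image loses much of the effect of compound 1 but still reads within the range of the assay.

The compounds shown leave open which of the stereocentres carries the step, as all three invert together in this pair, and a compound with only one of them inverted would be needed to divide it. Also open, from the compounds shown here alone, is how a carboxylic acid or a longer chain on the core of compound 1 would read in this assay, and whether the mirror image of such a compound would show a gap of similar size.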